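The compounds below may be only part of what the source reports. "The series", "measured", "known", "first", "only" and "open" are said of these compounds alone.

Three compounds are compared here, all built on one shared core and differing only in the group attached to a carbonyl carbon whose other neighbour is an amide-type nitrogen. Compound 1 `COc1cc(-c2nn(-c3cccc(NC(=O)c4cccc(C(F)(F)F)c4)c3)cc2-c2ccncc2)ccc1Cl` gives 1550 nM in a functional assay on HCT-15 cells (Homo sapiens) for inhibition, read by sulforhodamine B assay, with a stated time of 48 h; on this read-out higher numbers stand for weaker inhibition of growth and lower numbers for stronger inhibition of growth. Compound 2 `COc1cc(-c2nn(-c3cccc(NC(=O)Nc4cccc(C(F)(F)F)c4)c3)cc2-c2ccncc2)ccc1Cl` gives 870 nM in this assay. Compound 3 `COc1cc(-c2nn(-c3cccc(NC(=O)c4ccc(Cl)c(C(F)(F)F)c4)c3)cc2-c2ccncc2)ccc1Cl` gives 3250 nM in this assay, the highest number of the three: the step of a 2.1-fold higher number from compound 1 to compound 3 (0.32 log units; beyond the scatter) and the step of a 3.7-fold higher number from compound 2 to compound 3 (0.57 log units; beyond the scatter) both lie beyond the scatter, so compound 3 is the weakest growth inhibitor of the measured set.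

Compound 4 `COc1cc(-c2nn(-c3cccc(NC(=O)Nc4ccc(Cl)c(C(F)(F)F)c4)c3)cc2-c2ccncc2)ccc1Cl` has not yet been measured. It differs from compound 3 in one place: (4-chloro-3-(trifluoromethyl)phenyl)amino in place of 4-chloro-3-(trifluoromethyl)phenyl on a carbonyl carbon. The same kind of exchange, an aryl group giving way to an arylamino group on the carbonyl carbon, has already been seen once, as the step of a 1.8-fold lower number from compound 1 to compound 2 (0.25 log units; within the scatter), which stayed within the scatter. Among the measured compounds shown here, that is the only measured step that bears on the change, so only a small shift, if any, toward a lower number is expected for compound 4, and it is estimated as a 1.7-fold lower number from compound 3 to compound 4 (0.23 log units; within the scatter). On that basis compound 4 is expected to give about 1900 nM in this assay, with a likely range from 900 nM to 4000 nM.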

Compound 4, concentration for 50% growth inhibition: 1230 nM
For compound 4 the middle estimate is 1.5-fold (0.19 log units) above the measured one; measured number inside the range.
By their numbers in this assay, from the lowest: compounds 2, 4 and 1 (each within the scatter of the next); then compound 3.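

Once the 4-chloro-3-(trifluoromethyl)phenyl group is present, exchanging the aryl group for its arylamino counterpart on the carbonyl carbon gives a step beyond the scatter in this assay, a 2.6-fold lower number from compound 3 to compound 4 (0.42 log units; beyond the scatter), whereas the same kind of exchange without the chloro stayed within it. Adding the chloro to the arylamino compounds gives only a 1.4-fold higher number from compound 2 to compound 4 (0.15 log units; within the scatter), and making both changes at once gives a 1.3-fold lower number from compound 1 to compound 4 (0.10 log units; within the scatter), so in this small set the chloro separates compounds clearly only on the aryl side, with compound 3 standing apart from the other three. Even so, this difference between the two sides is not firm, since the chloro steps themselves cannot be told apart: the same change on two cores in this assay, a 2.1-fold higher number (0.32 log units; beyond the scatter) from compound 1 to compound 3 and a 1.4-fold higher number (0.15 log units; within the scatter) from compound 2 to compound 4, 1.5-fold (0.17 log units) apart, within the scatter of two such steps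

What the compounds shown leave open is whether the amino nitrogen itself matters, which an oxygen or a methylene group in its place on the carbonyl carbon would help to test. They also leave open whether the pattern holds when the chloro is replaced by a fluoro or a methoxy group.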